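The compounds below may be only part of what the source reports. "The series", "measured", "known", "first", "only" and "open" are said of these compounds alone.

Working notes on the series. Compound 1 `O=C(/C=C/[C@H]1C[C@@H](O)[C@@H](O)C1)Nc1ccccc1`, compound 2 `NC(=O)/C=C/[C@H]1C[C@@H](O)[C@@H](O)C1` and compound 3 `CNC(=O)/C=C/[C@H]1C[C@@H](O)[C@@H](O)C1` share one core and differ only in the group on the amide-type nitrogen. In an ADME assay on S2 cells (Drosophila melanogaster) for cytotoxicity, read by MTT assay (a lower number here means that less compound is needed, a higher number that more compound is needed for the effect), compound 1 gives only a limit, > 200000 nM. Compound 2 also gives only a limit in this assay, > 250000 nM. Compound 3 likewise gives only a limit in this assay, > 250000 nM. Compound 3 thus stands at the limit of > 250000 nM in this assay, at which 2 of the 3 values shown sit. Compound 1 stands at the limit of > 200000 nM in this assay, at which 1 of the 3 values shown sits. Because all three values are limits, the steps a step that the two limits leave unreadable from compound 1 to compound 2, a step that the two limits leave unreadable from compound 1 to compound 3 and a step that the two limits leave unreadable from compound 2 to compound 3 cannot be read in size or direction.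

Compound 4 `O=C(/C=C/[C@H]1C[C@@H](O)[C@@H](O)C1)NC1CC1` is the next member; the change from compound 3 is cyclopropyl in place of methyl on an amide-type nitrogen. Among the measured compounds shown here, none of the measured steps bearing on the amide-type nitrogen is readable, so nothing in this set points to a step beyond the scatter in either direction. The expectation is that compound 4 in this assay again reaches only a limit, and the estimate is 250000 nM, in the range 100000 nM to 1000000 nM. The expected step is therefore a number no higher from compound 3 to compound 4 (the limit leaves the size open).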

Compound 4, half-maximal effective concentration: > 250000 nM
Compound 4 was reported as a limit (the forecaster's own chance of this, stated with the estimate: 90%); the middle value sits exactly at the limit.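

In this assay compound 4 again gives only a limit, > 250000 nM. The steps to compound 4 from compound 1, compound 2 and compound 3 cannot be read in size or direction. The compounds shown leave open whether any group on the amide-type nitrogen gives a readable value in this assay.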